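One group exchanged where every value is a limit

The source may hold more compounds than are shown below. What is called first, only, known or untested is meant among the compounds shown, and "the series" means these compounds.

In an ADME assay on HEK293 cells (Homo sapiens) for cytotoxicity, with a stated time of 72 h (on this read-out lower numbers stand for an effect already at smaller amounts and higher numbers for an effect only at larger amounts of compound), compound 2 `Cc1cc(NC(=O)c2cc([N+](=O)[O-])ccc2Cl)cc(-c2nc3ccccc3o2)c1O` gives > 25000 nM, which is a limit and not a number. Compound 1 `O=C(Nc1cccc(-c2nc3ccccc3s2)c1)c1cc([N+](=O)[O-])c(O)cc1Cl` also gives a limit, > 25000 nM. Compound 3 `O=C(Nc1ccc(F)c(-c2nc3ccccc3s2)c1)c1cc([N+](=O)[O-])ccc1Cl` gives the same kind of limit, > 25000 nM. Among the measured compounds shown here, the whole set therefore stands at the limit of > 25000 nM in this assay, at which 3 of the 3 values shown sit, and no measured pair shows what a single exchange does.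

Compound 4 `Cc1cc(NC(=O)c2cc([N+](=O)[O-])ccc2Cl)cc(-c2nc3ccccc3s2)c1O` has not been measured yet and differs from compound 2 in one place: 1,3-benzothiazol-2-yl in place of 1,3-benzoxazol-2-yl on an aromatic carbon. In words, 1,3-benzothiazol-2-yl takes the place of 1,3-benzoxazol-2-yl on an aromatic carbon, ortho to a hydroxy group. The entering group also occurs in compound 3, whose value is the limit > 25000 nM, so no step beyond the scatter is expected in this assay. The estimated step, a number no higher from compound 2 to compound 4 (the limit leaves the size open), is thus no larger than the usual scatter. Compound 4 is expected at 25000 nM, with an estimated range of 12000 nM to 50000 nM, and will most likely be reported only as a limit again.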

Compound 4, half-maximal effective concentration: > 25000 nM
Compound 4 gave a limit, no number; the forecaster's own chance of this, stated with the estimate: 85%; the middle value lies on the limit itself.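

Compound 2 and compound 4 each give only a limit, so no step can be read between them, and the whole set stays the same: the limit of > 25000 nM in this assay, at which 4 of the 4 values shown sit.

What remains open is whether 1,3-benzothiazol-2-yl in place of 1,3-benzoxazol-2-yl changes anything in this assay, and at what amount any of these compounds would show an effect.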